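Amide aryl swap on the pyrazole-bearing core

The source may hold more compounds than are shown below. What is called first, only, known or untested is meant among the compounds shown, and "the series" means these compounds.

Measured so far:
compound 1 `Cc1noc(C)c1-c1cnc(N)c(Oc2ccc(C(=O)Nc3cc(Cl)ccn3)cc2)n1` 70800 nM
compound 2 `Cn1cc(-c2cnc(N)c(Oc3ccc(C(=O)Nc4ccc(Cl)cc4)cc3)n2)cn1` 35800 nM

Going by the values given here, in a functional assay on U-87MG ATCC cells for inhibition, with U-87 MG (Homo sapiens) as the target, read by MTT assay, with a stated time of 72 h (a lower number here means a stronger inhibitor, a higher number a weaker inhibitor), compound 2 gives the lower of the two numbers so far; its nearest neighbour, compound 1, is within the usual scatter, so the two are not told apart by these data. Among the compounds with values here, compound 1 and compound 2 differ in two places, so no single step links them.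

Compound 3 `Cn1cc(-c2cnc(N)c(Oc3ccc(C(=O)Nc4cc(Cl)ccn4)cc3)n2)cn1` is the next compound, not yet measured. It carries the same core as compound 2 with 4-chloropyridin-2-yl in place of 4-chlorophenyl on an amide-type nitrogen. Within the data shown here, no measured pair isolates this change. Compound 1 holds the same 4-chloropyridin-2-yl amide on a different core and gives a number that is within the scatter of compound 2, which gives no reason to expect a step beyond the scatter in either direction. The change from compound 2 to compound 3 is therefore estimated as a 1.3-fold higher number from compound 2 to compound 3 (0.10 log units; within the scatter), essentially flat. For compound 3 the expected value in this assay is 45000 nM, with a range of 18000 nM to 120000 nM.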

Compound 3, half-maximal inhibitory concentration: 47900 nM
Compound 3: the middle estimate sits 1.1-fold (0.03 log units) below what was measured; the range from low to high includes it.
By their numbers in this assay, from the lowest: compounds 2, 3 and 1 (each within the scatter of the next).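

In this assay, going by these compounds alone, the first matched pair at the amide-type nitrogen, 4-chloropyridin-2-yl in place of 4-chlorophenyl, gives a 1.3-fold higher number from compound 2 to compound 3 (0.13 log units; within the scatter) and so does not separate these two groups at this position on the shared core. The second pair, 1-methyl-1H-pyrazol-4-yl in place of 3,5-dimethyl-1,2-oxazol-4-yl on an aromatic carbon, gives a 1.5-fold lower number from compound 1 to compound 3 (0.17 log units; within the scatter) with the 4-chloropyridin-2-yl amide held constant, so that change is not resolved either. Nothing at hand explains either step.

Open, from the compounds shown here alone, is whether an amine or a carboxylic acid in place of the chlorine on the amide aryl ring would move the number beyond the scatter. Also open, going by these compounds, is whether 4-chlorophenyl on the core of compound 1 would read the same as 4-chloropyridin-2-yl.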